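Swapping a nitrile for a trichloropyridinyloxy group

The source may hold more compounds than are shown below. What is called first, only, known or untested is meant among the compounds shown, and "the series" means these compounds.

Compound 1 `Cc1nc2ccccc2cc1C(=O)n1nc(C)c(C2CCCCO2)c1C` gives 143 ug/mL in an ADME assay on A549 cells (Homo sapiens) for cytotoxicity, read by MTT assay, with a stated time of 48 h; a higher number here means a weaker inhibitor, a lower number a stronger inhibitor.
Compound 2 `CC(=O)N1N=C(c2cc3ccccc3nc2C)CC1c1ccc(C#N)cc1` gives only a limit, > 200 ug/mL, in this assay.

Compound 2 therefore stands at the edge of what this assay can report: its value is a limit of the assay, not a number, as the limit of > 200 ug/mL in this assay, at which 1 of the 2 values shown sits, shows. Within the data shown here, no step between measured compounds is available here, so nothing measured tells how the move to compound 3 `CC(=O)N1N=C(c2cc3ccccc3nc2C)CC1c1ccc(Oc2nc(Cl)c(Cl)cc2Cl)cc1` will play out. The change is (3,5,6-trichloropyridin-2-yl)oxy in place of cyano on an aromatic carbon. Since compound 2 sits at a limit, a step from compound 2 to compound 3 in this assay can only be seen if compound 3 comes out lower; a moderate move downward is expected, an at least 2.0-fold lower number from compound 2 to compound 3 (0.30 log units; that floor lies within the scatter), though a result that again ends at the limit remains possible. Compound 3 is expected to give about 100 ug/mL, within a range from 40 ug/mL to 200 ug/mL.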

Compound 3, half-maximal inhibitory concentration: > 200 ug/mL
Compound 3 ended at the assay's limit; the forecaster's own chance of this, stated with the estimate: 35%; middle value at least 2.0-fold (0.30 log units) from the limit.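

Compound 2 and compound 3 both stop at a limit rather than a number in this assay, so no step from one to the other can be read: the limit of > 200 ug/mL in this assay, at which 2 of the 3 values shown sit.

The compounds shown leave open whether (3,5,6-trichloropyridin-2-yl)oxy in place of cyano changes the result at all, and in which direction.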